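The source may report more compounds than this note shows. Statements on the series, on what has been measured and on what is new or still open speak of the compounds shown alone.

Measured in a functional assay on L5178Y cells (Mus musculus) for inhibition, read by MTT assay, with a stated time of 24 h; on this read-out lower numbers stand for stronger inhibition and higher numbers for weaker inhibition:
- compound 1 `Oc1ccc([C@@H]2C/C(=N\Nc3ccc(Br)cn3)c3c(O)cc(O)cc3O2)cc1`: >= 11300 nM
- compound 2 `COc1cc(O)c2c(c1)O[C@H](c1ccc(O)cc1)C/C2=N\N`: >= 11300 nM

Compound 2 has no exact value on this scale. Its result of >= 11300 nM is a limit of the assay and not a number. Compound 1 gives >= 11300 nM, which is likewise a limit. Among the measured compounds shown here, the data so far therefore hold (the limit of >= 11300 nM in this assay, at which 2 of the 2 values shown sit), and no step between two measured numbers shows how large a structural change might be.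

The next compound, compound 3 `COc1cc(O)c2c(c1)O[C@H](c1ccc(O)cc1)C/C2=N\Nc1ccc(Br)cn1`, comes from compound 2 through one change: 5-bromopyridin-2-yl in place of hydrogen on an amine nitrogen. In words, this puts 5-bromopyridin-2-yl in place of hydrogen on an amine nitrogen.

The starting point of compound 2 is the limit >= 11300 nM, so in this assay no step beyond the usual scatter of repeated measurements is expected, although a modest gain in inhibition remains possible. The expected change an at least 1.0-fold lower number from compound 2 to compound 3 (0.01 log units; that floor lies within the scatter) is therefore small. For compound 3 the estimated value is 11000 nM, with an expected range of 4000 nM to 30000 nM.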

Compound 3, half-maximal inhibitory concentration: 4300 nM
The estimate for compound 3 lay 2.6-fold (0.41 log units) above the measured number; measured number inside the range.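

In this assay, among the compounds shown here, putting 5-bromopyridin-2-yl in place of hydrogen on an amine nitrogen gives an at least 2.6-fold lower number from compound 2 to compound 3 (0.41 log units; beyond the scatter), the first step that lies beyond the scatter. That group alone does not yield a measurable number, however: with methyl in place of hydrogen on an oxygen on an aromatic ring, the change reads an at least 2.6-fold lower number from compound 1 to compound 3 (0.41 log units; beyond the scatter), so among the compounds shown an exact number appears only where both groups are present. Both steps give only a minimum size and not an exact one, because each starts from a limit of the assay rather than a number: the limit of >= 11300 nM in this assay, at which 2 of the 3 values shown sit.

From the compounds shown here alone, it remains open whether the bromine or the pyridine ring carries the gain, and whether a plain phenyl ring or a 5-chloropyridin-2-yl group on the same nitrogen would give a similar number. Also open, going by these compounds, is whether a longer chain, such as ethyl in place of the methyl on the oxygen, would keep, strengthen or lose this inhibition.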